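A few compounds are considered here, and "the series" means these few. Any claim that something is new, unique, unknown or untested is made for them only; others in the source may bear on it.

Series notes. Compound 1 `CCOC(=O)c1sc2nc(-c3cccs3)cc(-c3ccccc3)c2c1N` carries an ethoxycarbonyl group on the shared core, and in an assay for inhibition of 15-hydroxyprostaglandin dehydrogenase [NAD(+)] (Homo sapiens), read by fluorescence, with a stated time of 15 min, in the presence of a further agent that is not named here (on this read-out lower numbers stand for stronger inhibition and higher numbers for weaker inhibition), compound 1 gives only a limit, > 7500 nM, not a number. Among the three values shown, compound 1 sits at the limit of > 7500 nM in this assay, at which 1 of the 3 values shown sits. Compound 2 `CCCC[S+]([O-])c1sc2nc(-c3nc(C)cs3)cc(-c3cnc(C)n3C)c2c1N` and compound 3 `CCCC[S+]([O-])c1sc2nc(-c3nccs3)cc(-c3ccc(CN)cc3)c2c1N` carry a butylsulfinyl group where compound 1 carries the ester, together with other ring substituents that differ from those of compound 1; in this assay compound 2 gives 2.8 nM and compound 3 gives 11.5 nM. Compound 4 `CCC[S+]([O-])c1sc2nc(-c3cccs3)cc(-c3ccccc3)c2c1N` is compound 1 with a group of 5 heavy atoms (3 carbon, 1 oxygen, 1 sulfur; no ring) in place of a group of 5 heavy atoms (3 carbon, 2 oxygen; no ring), on an aromatic carbon. Going by the values given here, no measured step between two compounds differing in one place is available, so the expectation rests on compound 2 and compound 3, whose sulfinyl-bearing structures give low numbers in this assay while compound 1 with its ester gives none. A large step toward stronger inhibition is therefore expected, an at least 75-fold lower number from compound 1 to compound 4 (1.87 log units; beyond the scatter), with wide uncertainty. For compound 4 the estimate in this assay is 100 nM, with a range from 15 nM to 1000 nM.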

Compound 4, half-maximal inhibitory concentration: 2.1 nM
The estimate for compound 4 lay 48-fold (1.68 log units) above the measured number, outside the stated range (below it).
By their numbers in this assay, from the lowest: compounds 4 and 2 (each within the scatter of the next); then compound 3. At a limit, above all of these: compound 1.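

In this assay, exchanging ethoxycarbonyl for the entering group of 5 heavy atoms, on this aromatic carbon next to the ring sulfur, gives an at least 3500-fold lower number from compound 1 to compound 4 (3.55 log units; beyond the scatter). The earlier low numbers came from sulfinyl-bearing compounds whose other ring substituents also differed from those of compound 1, whereas here the exchange stands alone and this one position accounts for the whole step. Compound 1 remains a limit and not a number: the limit of > 7500 nM in this assay, at which 1 of the 4 values shown sits.

The compounds shown do not separate the sulfinyl group from its chain, which a thioether, a sulfone, an amide or a longer chain at this position could do. As far as these compounds go, whether the step holds with other ring substituents also stays open, as neither compound 2 nor compound 3 has an ester counterpart.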